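Swapping One Aryl Group on a Double-Bonded Core

The source may hold more compounds than are shown below. What is called first, only, known or untested is meant among the compounds shown, and "the series" means these compounds.

Of the compounds shown here, three have been measured in an assay on isolated protein for inhibition of Alpha glucosidase (Homo sapiens), with stated times of 5 min and 15 min, tested at 50 uM; a higher number here means more inhibition at the concentration tested (going by the name of the read-out), a lower number less inhibition. Compound 1, with the structure `Cc1ccc(/C=C2\CCC/C(=C\c3ccccc3)C2=O)cc1`, gives 34.1%. Compound 2, `O=C(/C=C(O)/C=C/c1cccc(O)c1)c1ccccc1O`, gives 40.4%, and compound 3, `O=C(/C=C(O)/C=C/c1ccc(O)cc1)c1cc(Cl)ccc1O`, gives 45.3%. Compound 1 has the lowest number of the three, but the gap to compound 2 lies within the usual scatter of this kind of measurement, so the two cannot be told apart; only compound 3 stands beyond the scatter above compound 1.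

Compound 4, `O=C1/C(=C/c2ccccc2)CCC/C1=C\c1ccccc1Br`, shares the core of compound 1 and differs from it in one place: 2-bromophenyl in place of 4-methylphenyl on a double-bonded chain carbon bound to a double-bonded ring carbon. Both groups that are exchanged are single aromatic rings of the same size, without hydrogen-bond donors or acceptors, and without charge.

Among the measured compounds shown here, no pair of measured compounds differs in a single place, so no step is known from which the effect of this exchange could be read. Compound 2 and compound 3 differ from each other in more than one place and belong to a different core, so their numbers do not tell how this exchange behaves.

The step from compound 1 to compound 4 is therefore expected to be small, with a value of a number 1.9 percentage points higher from compound 1 to compound 4 (within the scatter), and not beyond the scatter in either direction. For compound 4 the estimate in this assay is 36%, within a range from 22% to 52%.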

Compound 4, a percentage reported as inhibition, at one concentration (the size of the read-out at that concentration, not a potency): 46.8%
Estimate against measurement, compound 4: 10.8 percentage points below; the range from low to high includes it.
By their numbers in this assay, from the lowest: compounds 1, 2, 3 and 4 (each within the scatter of the next, the first and the last beyond it).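

At this place, on a double-bonded chain carbon bound to a double-bonded ring carbon, the choice of aromatic group matters in this assay: putting 2-bromophenyl in place of 4-methylphenyl gives a number 12.7 percentage points higher from compound 1 to compound 4 (beyond the scatter). The two groups have the same count of heavy atoms, the same single six-membered aromatic ring of carbon only, no hydrogen-bond donors or acceptors and no net charge, so these counts alone do not tell them apart, even though the two compounds give different numbers. Nothing measured here explains why the number rises with this exchange.

The exchange alters two things at once, the substituent on the ring (bromine in place of methyl) and the number in the group's name, so the compounds shown cannot separate the two; a 4-bromophenyl or a 2-methylphenyl group at this place would be needed to do that. From the compounds shown here alone, how this place responds to a ring carrying an amine or a carboxylic acid also remains open.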